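The source may hold more compounds than are shown below. What is called first, only, known or untested is meant among the compounds shown, and "the series" means these compounds.

In an ADME assay on microsomes from liver (Mus musculus) for metabolic stability, read by HPLC, using NADPH, with a stated time of 60 min, tested at 1 uM, in the presence of a further agent that is not named here (a lower number here means that the compound disappears faster, a higher number that the compound lasts longer), compound 1 (`O=C(NNS(=O)(=O)c1ccccc1F)c1cc(F)cc(-n2cccn2)c1`) gives 0.0833 h and compound 2 (`Cc1cc(-c2ncccn2)cc(C(=O)NNS(=O)(=O)c2ccccc2)c1F`) gives 0.1 h as its half-life. Within the data shown here, these two values lie within the usual scatter of each other, so compound 2 stands level with compound 1 on the numbers so far. Compound 3 (`C=CCOc1cc(C)c(F)c(C(=O)NNS(=O)(=O)c2ccccc2)c1`) differs from compound 2 in one place, with allyloxy in place of pyrimidin-2-yl on an aromatic carbon, meta to a large group, meta to a methyl group and para to a fluoro group. Among the measured compounds shown here, no pair of measured compounds differs in one place only, so the data give no direct measure of this exchange. Compound 1 and compound 2 do carry different groups on their cores and still show no gap beyond the scatter. A change beyond the scatter in this assay is therefore not expected in either direction, and the expected move (no change at the digits printed from compound 2 to compound 3 (within the scatter)) stays small. Compound 3 is estimated at 0.1 h in a range expected to run from 0.05 h to 0.25 h when it is measured.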

Compound 3, half-life: < 0.0334 h
Compound 3 ended at the assay's limit; the forecaster's own chance of this, stated with the estimate: 15%; middle value at least 2.9-fold (0.47 log units) from the limit.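

In this assay, the exchange of pyrimidin-2-yl for allyloxy on this aromatic carbon, meta to a large group, meta to a methyl group and para to a fluoro group, gives an at least 2.9-fold lower number from compound 2 to compound 3 (0.47 log units; beyond the scatter). This is the first change in one place among the compounds shown, and it shows that the group at this position can move the half-life beyond the scatter, which compound 1 and compound 2, differing in more than one place, could not show. The full size of the step remains unknown, and what compound 3 carries is a limit and not a number: the limit of < 0.0334 h in this assay, at which 1 of the 3 values shown sits.

The compounds shown leave open whether the step goes with the double bond of the allyloxy group, with its oxygen, or with the departure of the pyrimidin-2-yl ring, and one exchange alters all three at once. On these data alone, a propoxy chain, a methoxy group or a phenyl ring at this position would tell these readings apart, and whether the same step would appear on the core of compound 1 also stays open.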